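A few compounds are considered here, and "the series" means these few. Any claim that something is new, unique, unknown or untested is made for them only; others in the source may bear on it.

Working notes on the series.

The shared core carries a sulfur-linked chain ending in an amide to a halogenated phenyl ring; the chain length and the halogen pattern vary. Compound 1 `Cn1c(Cc2nn(C)c(=O)c3ccccc23)nnc1SCCCCCCCCCCCCCCCC(=O)Nc1ccc(Cl)cc1Cl` gives 7300 nM in an assay on isolated protein (Mus musculus) for inhibition of IL15-IL15 receptor (Homo sapiens), read by resazurin assay, with stated times of 30 min and 2.5 days; a higher number here means a weaker inhibitor, a lower number a stronger inhibitor. Compound 2 `Cn1c(Cc2nn(C)c(=O)c3ccccc23)nnc1SCCCCCCCCCCC(=O)Nc1ccc(Cl)cc1` gives 20000 nM in this assay. Compound 3 `Cn1c(Cc2nn(C)c(=O)c3ccccc23)nnc1SCCCCCCCC(=O)Nc1ccc(I)cc1` gives 1300 nM in this assay. Compound 3 holds the lowest number of the three; the gap to compound 1 and the larger gap to compound 2 both lie beyond the scatter, so compound 3 reads as the strongest inhibitor of this set. Compound 2 and compound 1 differ from compound 3 in both chain length and halogen pattern, so neither pair isolates a single change.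

Compound 4 `Cn1c(Cc2nn(C)c(=O)c3ccccc23)nnc1SCCCCCCCC(=O)Nc1ccc(F)cc1F` is not yet measured. It differs from compound 3 in one place: 2,4-difluorophenyl in place of 4-iodophenyl on an amide-type nitrogen. No single-change comparison in the set informs this swap. A modest weakening is expected, since the measured data give no support for the 2,4-difluorophenyl variant matching compound 3. The expected step is a 3.1-fold higher number from compound 3 to compound 4 (0.49 log units; beyond the scatter). Compound 4 is estimated at 4000 nM in this assay, with a range from 1300 nM to 15000 nM.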

Compound 4, half-maximal inhibitory concentration: 2300 nM
Estimate against measurement, compound 4: 1.7-fold (0.24 log units) above, within the range that was stated.
By their numbers in this assay, from the lowest: compounds 3 and 4 (each within the scatter of the next); then compound 1; then compound 2.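

Among the compounds shown here, the swap of 4-iodophenyl for 2,4-difluorophenyl on the amide-type nitrogen gives the first single-change comparison: in this assay there is a 1.8-fold higher number from compound 3 to compound 4 (0.25 log units; within the scatter) and so the two groups cannot be told apart on this chain. The earlier compounds shown here could not show this, since each of their pairs differs in both chain length and halogen pattern. At this chain length, iodine is not required for a number at this level, and a ring with two fluorines serves equally well. No supporting data bear on why the two groups read alike.

From the compounds shown here alone, whether an unsubstituted phenyl, a methoxy group or a carboxylic acid on this ring would read alike remains open. The effect of chain length alone cannot be read from the compounds shown.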